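The source may report more compounds than this note shows. Statements on the series, on what has been measured and on what is new or still open speak of the compounds shown alone.

Compound 1 `CC(C)C[C@H](N)c1cc(C(F)(F)F)ccc1N1CCN(C(=O)CCC(=O)N(C)C)CC1`: > 10000 nM in an assay on HEK293 cells for displacement of a labelled ligand from Melanocortin receptor 4 (Homo sapiens) (on this read-out lower numbers stand for stronger inhibition and higher numbers for weaker inhibition), a limit of the assay and not a number.
Compound 2 `CC(C)C[C@H](N)c1cc(C(F)(F)F)ccc1N1CCN(C(=O)COc2ccc(Cl)cc2)CC1`: 2900 nM in this assay.

Among the compounds with values here, compound 2 holds the only number in this set. The value of compound 1 sits at the limit of > 10000 nM in this assay, at which 1 of the 2 values shown sits. Within the data shown here, the measured step of an at least 3.4-fold lower number from compound 1 to compound 2 (0.53 log units; beyond the scatter) is the one change at the carbonyl and bears on the next step. Compound 3 `COc1ccc(CC(C)C(=O)N2CCN(c3ccc(C(F)(F)F)cc3[C@@H](N)CC(C)C)CC2)cc1F` brings (1-(3-fluoro-4-methoxybenzyl)ethyl in place of (4-chlorophenoxy)methyl on a carbonyl carbon). With the aromatic ring kept and the chain extended, a modest step downward is expected, a 1.9-fold lower number from compound 2 to compound 3 (0.29 log units; within the scatter). Compound 3 is estimated at 1500 nM, between 400 nM and 6000 nM.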

Compound 3, inhibition constant: 200 nM
Estimate against measurement, compound 3: 7.5-fold (0.88 log units) above, outside the stated range (below it).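

Replacing (4-chlorophenoxy)methyl with 1-(3-fluoro-4-methoxybenzyl)ethyl on the carbonyl carbon gives a 15-fold lower number from compound 2 to compound 3 (1.16 log units; beyond the scatter) in this assay, so this position still responds strongly when one six-membered aromatic ring of carbon only is present on both sides of the change. Against 2-(dimethylcarbamoyl)ethyl, the same group gives an at least 50-fold lower number from compound 1 to compound 3 (1.69 log units; beyond the scatter). That step rests on a limit and not a number: the limit of > 10000 nM in this assay, at which 1 of the 3 values shown sits.

The step from compound 2 to compound 3 alters the chain and the ring substituents together, and the compounds shown do not separate them. On these data alone, how an amine or a longer chain at this place would read in this assay stays open.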